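The source may hold more compounds than are shown below. What is called first, only, known or untested is meant among the compounds shown, and "the series" means these compounds.

Working notes on the pyrazolyl-enone series. Three compounds have been run in a functional assay on PC-3 cells (Homo sapiens) for inhibition, read by sulforhodamine B assay, with a stated time of 48 h; on this read-out higher numbers stand for weaker inhibition of growth and lower numbers for stronger inhibition of growth: compound 1 `COc1ccc(-c2cc(/C=C/C(=O)c3ccc(OC)c(OC)c3)[nH]n2)cc1`, compound 2 `COc1cc(-c2cc(/C=C/C(=O)c3ccc(Cl)c(Cl)c3)[nH]n2)cc(OC)c1OC` and compound 3 `COc1ccc(-c2cc(/C=C/C(=O)c3ccc(N)cc3)[nH]n2)cc1OC`. In this assay compound 1 gives 1450 nM, compound 2 gives 5950 nM and compound 3 gives 3710 nM. Compound 2 stands at the highest of the three numbers; its gap to compound 3 lies within the scatter, its gap to compound 1 lies beyond it. The next compound, compound 4 `COc1ccc(C(=O)/C=C/c2cc(-c3cc(OC)c(OC)c(OC)c3)n[nH]2)cc1OC`, is not yet measured in this assay. It differs from compound 2 in one place: 3,4-dimethoxyphenyl in place of 3,4-dichlorophenyl on a carbonyl carbon. Compound 1 also carries the 3,4-dimethoxyphenyl on the carbonyl carbon and gives the lowest number seen, so a step toward a lower number is expected, a 3.0-fold lower number from compound 2 to compound 4 (0.47 log units; beyond the scatter). Compound 4 is estimated at 2000 nM, in the range 800 nM to 5000 nM.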

Compound 4, concentration for 50% growth inhibition: 1360 nM
Compound 4: the middle estimate sits 1.5-fold (0.17 log units) above what was measured, within the range that was stated.
By their numbers in this assay, from the lowest: compounds 4 and 1 (each within the scatter of the next); then compounds 3 and 2 (each within the scatter of the next).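

For the compounds shown here, on the carbonyl carbon, this is the first one-place comparison: in this assay, 3,4-dimethoxyphenyl in place of 3,4-dichlorophenyl gives a 4.4-fold lower number from compound 2 to compound 4 (0.64 log units; beyond the scatter) with the rest of the structure held constant. The number at this position therefore responds to the group it carries, by more than the usual scatter. No measurement shown here accounts for the step.

On these data alone, how a carboxylic acid or a morpholine at this position would read remains open. So does whether the same change holds on a different core.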